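An aryl swap on compound 3 in a cytotoxicity test

The compounds below may be only part of what the source reports. "The series", "measured", "known", "first", "only" and "open" are said of these compounds alone.

In an ADME assay on MT2 cells (Homo sapiens) for cytotoxicity, read by XTT assay, with a stated time of 4 days (on this read-out lower numbers stand for higher toxicity in this test and higher numbers for lower toxicity in this test), compound 3 (`Cc1nc(C(NC(=O)C(=O)Nc2ccc(Cl)c(F)c2)C2CCCCN2)sc1CCO`) has no exact number, only a limit of > 41000 nM. Compound 1 (`Cc1nc(C(NC(=O)C(=O)Nc2ccc(Cl)cc2)C2CCNCC2)sc1CCO`) is likewise reported only as a limit, > 78500 nM. Compound 2 (`Cc1nc(C(NC(=O)C(=O)Nc2ccc(Cl)c(F)c2)C2CCCCN2)sc1CO`) is the only one of the three with a measured number, 77800 nM.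

The next compound to be tested is compound 4 (`CC(=O)c1ccc(NC(=O)C(=O)NC(c2nc(C)c(CCO)s2)C2CCCCN2)cc1`), which differs from compound 3 at one place: 4-acetylphenyl in place of 4-chloro-3-fluorophenyl on an amide-type nitrogen. Within the data shown here, only one measured step bears on the series, a step that the limit leaves unreadable from compound 2 to compound 3. It concerns the hydroxy-bearing chain and not the group that changes here, and its size cannot be read, so it offers no size to carry over. None of the three measured compounds carries 4-acetylphenyl.

Among the measured compounds shown here, with no measured step at this place, no shift beyond the usual scatter is expected, and no direction can be favoured. The estimate therefore rests on the level of compound 2 at 77800 nM. The expected change is small, a step that the limit leaves unreadable from compound 3 to compound 4. A report of only a limit would fit what has been seen so far. In this assay, compound 4 is expected at 70000 nM, with an estimated range from 30000 nM to 150000 nM.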

Compound 4, half-maximal cytotoxic concentration: > 48300 nM
Compound 4: only a limit was reported (the forecaster's own chance of this, stated with the estimate: 65%); the middle value does not contradict the limit.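

No step can be read from compound 3 to compound 4 in this assay: each of the two compounds is reported only as a limit. The compounds shown leave open whether 4-acetylphenyl in place of 4-chloro-3-fluorophenyl on an amide-type nitrogen changes the half-maximal cytotoxic concentration at all, and if so, in which direction and by how much.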